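The source may report more compounds than this note shows. Statements on the series, on what has been measured and on what is new or still open speak of the compounds shown alone.

Compound 2 `COc1ccc(-c2cc(=O)c3c(OC)cc(OC)cc3n2S(=O)(=O)c2cccc([N+](=O)[O-])c2)cc1` has been run in a functional assay on SUP-B15 cells (Homo sapiens) for antiproliferative activity, with a stated time of 72 h; on this read-out higher numbers stand for an effect only at larger amounts of compound and lower numbers for an effect already at smaller amounts. In this assay compound 2 gives only a limit, > 39600 nM, and no number, so its position on the numbers shown is simply at that limit, at which one of the two values shown sits (the limit of > 39600 nM in this assay, at which 1 of the 2 values shown sits). Compound 1 `COc1ccc(-c2[nH]c3cc(OC)cc(OC)c3c(=O)c2I)cc1` is also measured in this assay. For compound 1 the result is likewise a limit, > 86200 nM, with no number behind it (the limit of > 86200 nM in this assay, at which 1 of the 2 values shown sits). Compound 3 `COc1ccc(-c2cc(=O)c3c(OC)cc(OC)cc3n2S(=O)(=O)c2ccc(OC)cc2)cc1` has not yet been measured in this assay. It differs from compound 2 by 4-methoxyphenyl in place of 3-nitrophenyl on a sulfonyl sulfur. With both measured compounds at limits in this assay, the step to compound 3 is expected to be none beyond the scatter, in no particular direction, and a further limit is the likely outcome. For compound 3 the estimate in this assay is 50000 nM, within 20000 nM to 120000 nM, which means an expected step that the limit leaves unreadable from compound 2 to compound 3.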

Compound 3, half-maximal effective concentration: > 82700 nM
Compound 3 ended at the assay's limit; the forecaster's own chance of this, stated with the estimate: 80%; middle value at least 1.6-fold (0.21 log units) from the limit.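

Among these compounds, compound 2 and compound 3 both sit at limits in this assay, so no step between them can be read. The compounds shown leave open whether 4-methoxyphenyl in place of 3-nitrophenyl on a sulfonyl sulfur changes antiproliferative activity at all.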